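Butyl for Isopropyl on Two Cores Against Myosin-2

The source may hold more compounds than are shown below. What is called first, only, known or untested is meant among the compounds shown, and "the series" means these compounds.

Compound 1 `C/C(=N\CC(C)C)c1c(O)c2ccccc2oc1=O` and compound 3 `CCCCC/N=C(\C)c1c(O)c2ccccc2oc1=O` share one core and differ in a single place: butyl in place of isopropyl on a saturated chain carbon bound to a double-bonded nitrogen. In an assay on isolated protein for inhibition of myosin-2 (Bos taurus), read by spectrophotometry, with a stated time of 24 min (a lower number here means a stronger inhibitor, a higher number a weaker inhibitor), compound 1 gives 34000 nM, and compound 3 gives 6700 nM. The step is a 5.1-fold lower number from compound 1 to compound 3 (0.71 log units; beyond the scatter). Compound 2 `C/C(=N\CC(C)C)c1c(O)c2ccccc2[nH]c1=O` rests on a different core, and the difference between the two cores is not broken down here. In this assay compound 2 gives only a limit of the assay, >= 100000 nM. That reading sits at the limit of >= 100000 nM in this assay, at which 1 of the 3 values shown sits. Compound 4 `CCCCC/N=C(\C)c1c(O)c2ccccc2[nH]c1=O` carries the same change on the core of compound 2: butyl in place of isopropyl on a saturated chain carbon bound to a double-bonded nitrogen. Because the earlier change gave a 5.1-fold lower number from compound 1 to compound 3 (0.71 log units; beyond the scatter), the same kind of change is expected to lower the number here as well. For compound 4 the expected step is an at least 2.5-fold lower number from compound 2 to compound 4 (0.39 log units; beyond the scatter), set beside that earlier step. The expectation rests on compound 3, which gave 6700 nM. The starting point of compound 2 is known only as a limit, so the result for compound 4 is uncertain. Compound 4 is estimated at 40000 nM, expected to fall between 10000 nM and 150000 nM.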

Compound 4, half-maximal inhibitory concentration: >= 100000 nM
Compound 4 gave a limit, no number; the forecaster's own chance of this, stated with the estimate: 30%; middle value at least 2.5-fold (0.39 log units) from the limit.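

In this assay compound 4 gives >= 100000 nM as a limit of the assay, not a number. Compound 2 also stands at a limit, so no step can be read from compound 2 to compound 4: the limit of >= 100000 nM in this assay, at which 2 of the 4 values shown sit. The compounds shown leave open whether the change seen from compound 1 to compound 3 carries over to the core of compound 2.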